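Trading 1H-indol-4-yl for phenyl in compound 1

The source may report more compounds than this note shows. Statements on the series, on what has been measured and on what is new or still open speak of the compounds shown alone.

In a physicochemical assay for lipophilicity, at pH 7.4 (on this read-out higher numbers stand for higher lipophilicity and lower numbers for lower lipophilicity), compound 1 `CNC(=O)c1cc(C(=O)NC2CC2)cc2c1OC[C@H]2c1cccc2[nH]ccc12` gives 3.5. This lies within the usual scatter of compound 3 `CNC(=O)c1cc(C(=O)N[C@H]2[C@@H]3COC[C@@H]32)cc2c1OC[C@@]2(C)c1ccccc1`, which gives 3.7. Compound 2 `CC[C@@]1(c2ccccc2)COc2c(C(=O)NC)cc(C(=O)N[C@H]3[C@@H]4COC[C@@H]43)cc21` gives 4.2, beyond the scatter from compound 1, whose number is the lower of the two.

Compound 4 `CNC(=O)c1cc(C(=O)NC2CC2)cc2c1OC[C@H]2c1ccccc1` has not yet been measured. It keeps the core of compound 1 and differs in one place, a saturated ring carbon: phenyl in place of 1H-indol-4-yl on a saturated ring carbon.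

Among the measured compounds shown here, no measured step makes this same swap. For the measured compounds named here, the only guide is a number 0.50 log units lower from compound 2 to compound 3 (beyond the scatter), a modest step in which hydrogen takes the place of methyl on a saturated chain carbon. That step also removes carbon, but in a different group and a different place, so it offers only loose support. On that basis, the expected change is a number 0.40 log units lower from compound 1 to compound 4 (beyond the scatter), of similar size and in the same direction. For compound 4, the estimated value in this assay is 3.1, with an expected range from 2.7 to 3.5.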

Compound 4, distribution coefficient: 3.6
For compound 4 the middle estimate is 0.50 log units below the measured one; the measured number lies above the stated range.
By their numbers in this assay, from the lowest: compounds 1, 4 and 3 (each within the scatter of the next); then compound 2.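

In this assay the swap gives a number 0.10 log units higher from compound 1 to compound 4 (within the scatter) and so, at this saturated ring carbon, the read-out does not separate phenyl from 1H-indol-4-yl. Among the compounds shown here, the group that leaves has 9 heavy atoms and 1 hydrogen-bond donor, the group that enters has 6 and no donor, and here that difference produces no step beyond the scatter, something the earlier compounds could not show, as their only step concerned hydrogen and methyl on a saturated chain carbon. Nothing in the data shown explains why these two groups read alike.

Still open, going by these compounds, is whether a quite different group on this carbon, such as an amine or a carboxylic acid, would also stay within the scatter of compound 1. On these data alone, it is equally open whether phenyl and 1H-indol-4-yl read alike on any core other than that of compound 1.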